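The source may report more compounds than this note shows. Statements on the series, on what has been measured and on what is new or still open speak of the compounds shown alone.

Compound 1 `N#Cc1ccnc(Oc2nn(C3CCC3)c3ncnc(N)c23)c1` gives 2.35 h in an ADME assay on microsomes from liver (Homo sapiens) for metabolic stability, read by LC-MS, using NADPH, with a stated time of 10 min, tested at 10 uM; a higher number here means that the compound lasts longer, a lower number that the compound disappears faster. Compound 2 `N#Cc1ccnc(Oc2nn(C3CC3)c3ncnc(N)c23)c1` reaches > 2.41 h, which is a limit of this assay rather than a number. Compound 3 `N#Cc1ccnc(Oc2nn([C@H]3C[C@@H](O)C3)c3ncnc(N)c23)c1` also reaches > 2.41 h, again a limit and not a number.

On these data alone, compound 3 therefore stands at the limit of > 2.41 h in this assay, at which 2 of the 3 values shown sit, so its exact half-life is unknown. Compound 4 `CC(C)(C)n1nc(Oc2cc(C#N)ccn2)c2c(N)ncnc21` differs from compound 3 by tert-butyl in place of 3-hydroxycyclobutyl on an aromatic nitrogen. Of the measured steps, an at least 1.0-fold higher number from compound 1 to compound 3 (0.01 log units; that floor lies within the scatter) and an at least 1.0-fold higher number from compound 1 to compound 2 (0.01 log units; that floor lies within the scatter) both stay within the scatter, and a step that the two limits leave unreadable from compound 2 to compound 3 cannot be read. Going by the values given here, no step points to a change beyond the scatter, so compound 4 is expected to sit near compound 3, with an at least 1.0-fold lower number from compound 3 to compound 4 (0.03 log units; that floor lies within the scatter). Compound 4 is thus estimated at 2.2 h, between 1.1 h and 4.4 h.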

Compound 4, half-life: > 2.41 h
Compound 4 was reported as a limit (the forecaster's own chance of this, stated with the estimate: 45%); at least 1.0-fold (0.03 log units) between middle value and limit.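

In this assay compound 4 gives > 2.41 h as a limit of the assay and not a number. On this aromatic nitrogen tert-butyl, with no ring and no hydrogen-bond donor, now reaches the same limit as cyclopropyl and 3-hydroxycyclobutyl: the limit of > 2.41 h in this assay, at which 3 of the 4 values shown sit. Going by these compounds alone, the one step that can be read is an at least 1.0-fold higher number from compound 1 to compound 4 (0.01 log units; that floor lies within the scatter) and it shows no change beyond the scatter, while the steps among compound 2, compound 3 and compound 4 cannot be read. On these data alone, how far these three compounds lie past the limit stays open, and so does whether a group carrying an amine or a carboxylic acid on this nitrogen would also reach it.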